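The compounds below may be only part of what the source reports. "The series", "measured", "known", "first", "only" and "open" are said of these compounds alone.

In an assay on LtK cells with ATP-sensitive inward rectifier potassium channel 11 (Homo sapiens) as the target (on this read-out lower numbers stand for an effect already at smaller amounts and higher numbers for an effect only at larger amounts of compound), compound 3 `O=C(Nc1c(C(O)(C(F)(F)F)C(F)(F)F)ccc2ccccc12)c1cccc([N+](=O)[O-])c1` gives 117 nM, the lowest of the two numbers on hand; compound 1 `CCC(CC)C(=O)Nc1c(C(O)(C(F)(F)F)C(F)(F)F)ccc2ccccc12` gives 4340 nM. Compound 2 `CCCC(C)C(=O)Nc1c(C(O)(C(F)(F)F)C(F)(F)F)ccc2ccccc12` reaches only the limit > 10000 nM (the limit of > 10000 nM in this assay, at which 1 of the 3 values shown sits). The steps of a 37-fold lower number from compound 1 to compound 3 (1.57 log units; beyond the scatter) and an at least 85-fold lower number from compound 2 to compound 3 (1.93 log units; beyond the scatter) both put an aromatic ring in place of a chain on the carbonyl carbon, and both are large. Compound 4 `O=C(Nc1c(C(O)(C(F)(F)F)C(F)(F)F)ccc2ccccc12)c1ccc(OC(F)(F)F)cc1` differs from compound 3 by 4-(trifluoromethoxy)phenyl in place of 3-nitrophenyl on a carbonyl carbon. Among the compounds with values here, no measured step exchanges one aromatic ring for another, so those two steps only frame the range in which aromatic amides sit. The expected step is a 1.3-fold higher number from compound 3 to compound 4 (0.11 log units; within the scatter) in this assay, none beyond the scatter. Compound 4 is therefore estimated at 150 nM in this assay, between 50 nM and 500 nM.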

Compound 4, half-maximal effective concentration: > 10000 nM
Compound 4 gave a limit, no number; the forecaster's own chance of this, stated with the estimate: 5%; middle value at least 66-fold (1.82 log units) from the limit.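

Replacing 3-nitrophenyl with 4-(trifluoromethoxy)phenyl on the carbonyl carbon gives an at least 85-fold higher number from compound 3 to compound 4 (1.93 log units; beyond the scatter), so in this assay an aromatic ring here does not by itself secure a low number. Against pentan-3-yl, the same group gives an at least 2.3-fold higher number from compound 1 to compound 4 (0.36 log units; beyond the scatter), opposite in direction to the 3-nitrophenyl step. Compound 4 stands at a limit, not a number: the limit of > 10000 nM in this assay, at which 2 of the 4 values shown sit.

The step between compound 2 and compound 4 cannot be read. Still open, on these data alone, is whether the ring substituent or its ring position decides the outcome, which 4-nitrophenyl, 3-(trifluoromethoxy)phenyl or unsubstituted phenyl would separate.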